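The source may report more compounds than this note shows. Statements on the series, on what has been measured and on what is new or still open speak of the compounds shown alone.

Compound 3 `Nc1scc(-c2cccc(Br)c2)c1C(=O)c1ccc(Cl)cc1` stands highest of the three measured compounds in a functional assay on CHO cells for agonist activity at adenosine receptor A1 (Homo sapiens), read by fluorescence and ERK phosphorylation, with stated times of 30 min and 1.5 h, tested at 3 uM; on this read-out higher numbers stand for a stronger effect at the one concentration tested and lower numbers for a weaker effect: compound 3 gives 62%, whereas compound 1 `Nc1scc(-c2ccccc2)c1C(=O)c1ccc(Cl)cc1` gives 51% and compound 2 `Nc1scc(-c2ccc(Cl)cc2)c1C(=O)c1ccc(Cl)cc1` gives 50%. The step of a number 11 percentage points higher from compound 1 to compound 3 (beyond the scatter) is modest but beyond the scatter, as is a number 12 percentage points higher from compound 2 to compound 3 (beyond the scatter), while the step of a number 1 percentage points lower from compound 1 to compound 2 (within the scatter) lies within the scatter. Compound 4 `Nc1scc(-c2ccc(Br)cc2)c1C(=O)c1ccc(Cl)cc1` has not yet been measured; it differs from compound 3 in a single place, (4-bromophenyl in place of 3-bromophenyl on an aromatic carbon). Among the measured compounds shown here, two measured steps bear on this. Compound 2, which carries a 4-chlorophenyl, gave a number 1 percentage points lower from compound 1 to compound 2 (within the scatter), that is no gain over hydrogen, whereas compound 3, carrying a 3-bromophenyl, gave a number 11 percentage points higher from compound 1 to compound 3 (beyond the scatter). Compound 4 carries a 4-bromophenyl, so it resembles compound 2 in where its halogen sits and compound 3 in which halogen it is; no bromo has been tested in that arrangement. The step of a number 8 percentage points lower from compound 3 to compound 4 (within the scatter) is therefore expected to be a modest fall, back toward the level of compounds 1 and 2. Compound 4 is estimated at 54%, with a range from 42% to 66%.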

Compound 4, a percentage reported as activity, at one concentration (the size of the read-out at that concentration, not a potency): 45%
The estimate for compound 4 lay 9 percentage points above the measured number; the range from low to high includes it.
By their numbers in this assay, from the lowest: compounds 4, 2 and 1 (each within the scatter of the next); then compound 3.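

In this assay, the change from 3-bromophenyl to 4-bromophenyl on the same aromatic carbon, with the same atoms joined differently, gives a number 17 percentage points lower from compound 3 to compound 4 (beyond the scatter), so bromine alone does not account for the higher number of compound 3; among these compounds, that higher number appears only with the 3-bromophenyl group. The 4-bromophenyl group, by contrast, stands apart from neither neighbour, with a number 5 percentage points lower from compound 2 to compound 4 (within the scatter) and a number 6 percentage points lower from compound 1 to compound 4 (within the scatter), both small enough to be ordinary scatter. No measurement here explains why the two bromophenyl groups differ.

As far as these compounds go, whether a 3-chlorophenyl group would match the 3-bromophenyl group remains open. So does the effect of a methoxy group or an amine on the phenyl ring, and a single tested concentration cannot show potency.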